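Methyl for hydrogen on the core of compound 3

This account rests on a few compounds, and the source may have more. Where it says the series, first, only, none or still open, it means among the compounds named here.

In an ADME assay on microsomes from liver (Rattus norvegicus), read by LC-MS, using NADPH, with a stated time of 30 min, tested at 1 uM (a higher number here means that more of the compound is left, a lower number that less of the compound is left), compound 1 `C[C@H](Nc1nc(N)nc(N)c1C#N)c1cc2ccc(F)cn2c(=O)c1-c1ccccc1` gives 88%. Compound 2 `C[C@H](Nc1ccnc(N)n1)c1cc2ccc(F)cn2c(=O)c1-c1ccccc1` gives "not determined" (no result reported) in this assay. Compound 3 `Cc1nc(N)nc(N[C@@H](C)c2cc3ccc(F)cn3c(=O)c2-c2ccccc2)c1C#N` gives 41%, the lower of the two numbers available; the step of a number 47 percentage points lower from compound 1 to compound 3 (beyond the scatter) covers methyl in place of amino on an aromatic carbon. Compound 4 `Cc1nc(N)nc(N[C@@H](C)c2c(-c3ccccc3)c(=O)n3cc(F)ccc3c2C)c1C#N` differs from compound 3 by methyl in place of hydrogen on an aromatic carbon. For the measured compounds named here, no measured step matches this change: the single step known concerns a different group and a different place and offers no guide to methyl for hydrogen on the core. With nothing pointing either way, compound 4 is expected to show a step of a number 1 percentage points lower from compound 3 to compound 4 (within the scatter) in this assay, within the scatter. The estimate for compound 4 is 40%, with a range from 15% to 65%.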

Compound 4, percent of the compound remaining: 91%
Compound 4: the middle estimate sits 51 percentage points below what was measured; the measured number lies above the stated range.
By their numbers in this assay, from the lowest: compound 3; then compounds 1 and 4 (each within the scatter of the next).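

In this assay, methyl in place of hydrogen on an aromatic carbon of the core gives a number 50 percentage points higher from compound 3 to compound 4 (beyond the scatter), so the number responds strongly to one added heavy atom at this position, ortho to a large group. For the compounds shown here, the only earlier step, a number 47 percentage points lower from compound 1 to compound 3 (beyond the scatter), concerned a different place and showed nothing about the core. Nothing measured here gives a cause for this step.

As far as these compounds go, whether an ethyl group or fluorine at this carbon would give a similar number remains open. Also open, from the compounds shown here alone, is whether the same methyl would change the number on the core of compound 1.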